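Triazole N-aryl variation in a methoxy-styryl ketone series

The source may hold more compounds than are shown below. What is called first, only, known or untested is meant among the compounds shown, and "the series" means these compounds.

Measured compounds:
compound 1 `COc1cc(/C=C/C(C)=O)ccc1OCc1cn(-c2c(F)cccc2F)nn1` 24200 nM
compound 2 `COc1cc(/C=C/C(C)=O)ccc1OCc1cn(-c2c(Cl)cccc2Cl)nn1` 3070 nM
compound 3 `COc1cc(/C=C/C(C)=O)ccc1OCc1cn(-c2ccc(C=O)cc2)nn1` 80700 nM

In a functional assay on PC-3 cells (Homo sapiens) for antiproliferative activity, read by MTT assay, with a stated time of 48 h (a lower number here means a stronger inhibitor, a higher number a weaker inhibitor), compound 2 gives the lowest number of the three: a 7.9-fold lower number from compound 1 to compound 2 (0.90 log units; beyond the scatter) and a 26-fold higher number from compound 2 to compound 3 (1.42 log units; beyond the scatter) both lie beyond the scatter. Compound 4 `COc1cc(/C=C/C(C)=O)ccc1OCc1cn(-c2ccccc2)nn1` changes compound 2 by phenyl in place of 2,6-dichlorophenyl on an aromatic nitrogen. Both measured steps bear on this: the swap of 2,6-difluorophenyl for 2,6-dichlorophenyl lowered the number modestly, and the swap of 2,6-dichlorophenyl for 4-formylphenyl raised it by a large step. Removing both chlorines from the 2,6-dichlorophenyl is therefore expected to raise the number in this assay, with a 4.9-fold higher number from compound 2 to compound 4 (0.69 log units; beyond the scatter) as the expected step. For compound 4 the estimate is 15000 nM, with a range of 5000 nM to 50000 nM.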

Compound 4, half-maximal inhibitory concentration: 78600 nM
The estimate for compound 4 lay 5.2-fold (0.72 log units) below the measured number; the measured number lies above the stated range.
By their numbers in this assay, from the lowest: compound 2; then compound 1; then compounds 4 and 3 (each within the scatter of the next).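

In this assay, bare phenyl loses all the advantage of the 2,6-dichlorophenyl, with a 26-fold higher number from compound 2 to compound 4 (1.41 log units; beyond the scatter), so the gain in compound 2 depends on the two chlorines and not on the aryl ring alone. The 2,6-difluorophenyl also keeps an edge over phenyl, with a 3.2-fold higher number from compound 1 to compound 4 (0.51 log units; beyond the scatter), whereas formyl and hydrogen on the ring are not told apart, with a 1.0-fold lower number from compound 3 to compound 4 (0.01 log units; within the scatter). No measurement available here accounts for these steps.

On these data alone, whether a single chlorine is enough remains open. So does whether 2,6-dibromophenyl or 2,6-dimethylphenyl would match the 2,6-dichlorophenyl.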